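The source may hold more compounds than are shown below. What is called first, only, known or untested is meant among the compounds shown, and "the series" means these compounds.

Of the compounds shown here, three have been measured in a functional assay on Huh-7 cells (Homo sapiens) for cytotoxicity, read by resazurin assay, with a stated time of 48 h; a higher number here means a weaker inhibitor, a lower number a stronger inhibitor. Compound 1 `C=CCN/C(SC)=C(/C#N)C(=O)Nc1ccc(OCC)cc1` gives 8850 nM in this assay. Compound 2 `CCOc1ccc(NC(=O)CC#N)cc1` gives 21500 nM in this assay, and compound 3 `CCOc1ccc(-n2nnc3n[nH]c(Nc4ccccc4)c3c2=O)cc1` gives 9390 nM in this assay. Compound 1 carries the lowest number of the three; its gap to compound 3 lies within the scatter, so these two cannot be ordered, while its gap to compound 2 lies beyond the scatter.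

Compound 4 `CCOc1ccc(NC(=O)/C(C#N)=C(\NC)SC)cc1` is not yet measured in this assay. It differs from compound 1 in one place: hydrogen in place of vinyl on a saturated chain carbon bound to an amine nitrogen. Cut one bond further out, the change reads allyl to methyl, allylamino to methylamino. Within the data shown here, no measured pair in the set shows this change, so no step is available to anchor an expectation. The change is small, and no shift beyond the scatter in this assay is expected in either direction. The expected step is a 1.1-fold higher number from compound 1 to compound 4 (0.03 log units; within the scatter), that is, none beyond the scatter. For compound 4 the expected value in this assay is 9500 nM, within a range from 4500 nM to 20000 nM.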

Compound 4, half-maximal inhibitory concentration: 5780 nM
Estimate against measurement, compound 4: 1.6-fold (0.22 log units) above; low and high end bracket the measured number.
By their numbers in this assay, from the lowest: compounds 4, 1 and 3 (each within the scatter of the next); then compound 2.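

In this assay, the saturated chain carbon bound to an amine nitrogen gives the series its first readable step: hydrogen in place of vinyl, allylamino to methylamino, gives a 1.5-fold lower number from compound 1 to compound 4 (0.19 log units; within the scatter). In this one pair, the loss of the vinyl group, with its 2 heavy atoms and its double bond outside aromatic rings, leaves the number within the scatter, so that double bond is not required to keep the value at the level of compound 1. Nothing available accounts for the step or links it to any property of the group.

From the compounds shown here alone, whether a longer chain, such as butyl, or a benzyl group on this amine nitrogen would also stay within the scatter of compound 1 remains open. A single pair also leaves open whether the same change would read alike on another core.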